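The source may report more compounds than this note shows. Statements on the series, on what has been measured and on what is new or still open speak of the compounds shown alone.

Measured compounds in the series:
- compound 1 `CCOC(=O)C1=C(Nc2ccccc2)S/C(=C\c2ccc(Br)c(O)c2)C1=O`: in a functional assay on JAR cells (Homo sapiens) for inhibition, read by MTT assay, with a stated time of 72 h, tested at 10 uM (on this read-out lower numbers stand for less inhibition and higher numbers for more inhibition at the one concentration tested (going by the name of the read-out)), compound 1 gives 39.8%
- compound 2 `CCOC(=O)C1=C(Nc2ccccc2)S/C(=C\c2ccccc2O)C1=O`: compound 2 gives 89.4%
- compound 3 `CCOC(=O)C1=C(Nc2ccccc2)S/C(=C\c2ccc[nH]2)C1=O`: compound 3 gives 49.2%

Compound 3 stands second highest of the three numbers. Its nearest neighbour is compound 1, the step being a number 9.4 percentage points higher from compound 1 to compound 3 (within the scatter), so the two cannot be told apart on this read-out. The only clear separation in the set is from compound 2: a number 40.2 percentage points lower from compound 2 to compound 3 (beyond the scatter). Compound 2 against compound 1 shows the same kind of gap, a number 49.6 percentage points higher from compound 1 to compound 2 (beyond the scatter).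

Compound 4 `CCOC(=O)C1=C(Nc2ccc([N+](=O)[O-])cc2)S/C(=C\c2ccc[nH]2)C1=O` is the next member. It differs from compound 3 by nitro in place of hydrogen on an aromatic carbon. All three measured steps alter the group on the double-bonded chain carbon bound to a double-bonded ring carbon; none of them touches the phenyl on the nitrogen of the shared core. Within the data shown here, there is therefore no measured step that bears on this change, and the data give no basis for expecting movement in either direction. The step from compound 3 to compound 4 is expected to stay within the scatter, a number 0.2 percentage points lower from compound 3 to compound 4 (within the scatter). Compound 4 is estimated at 49%, with a range from 25% to 75% to reflect the absence of any comparable step.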

Compound 4, a percentage reported as inhibition, at one concentration (the size of the read-out at that concentration, not a potency): 54.9%
Compound 4: the middle estimate sits 5.9 percentage points below what was measured; the measured number falls inside the stated range.
By their numbers in this assay, from the lowest: compounds 1, 3 and 4 (each within the scatter of the next, the first and the last beyond it); then compound 2.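

In this assay the change from phenyl to 4-nitrophenyl gives a number 5.7 percentage points higher from compound 3 to compound 4 (within the scatter), so compound 3 and compound 4 cannot be told apart on this read-out. Among these compounds, the earlier steps all altered the group on the double-bonded chain carbon, whereas this is the first reading of a change on the phenyl of the shared core, and with 1H-pyrrol-2-yl held constant, nitro on this aromatic carbon, para to a large group, produces no separation. No measurement available here accounts for this result.

As far as these compounds go, it remains open whether nitro at this place would also leave the read-out unresolved with the 2-hydroxyphenyl group of compound 2 , which gives 89.4% in this assay, since the present step covers only the 1H-pyrrol-2-yl pair. Also open, from the compounds shown here alone, is what an amine or a carboxylic acid would give on the same aromatic carbon of the phenyl, with 1H-pyrrol-2-yl or 2-hydroxyphenyl on the chain carbon.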